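The source may hold more compounds than are shown below. What is called first, only, known or untested is meant among the compounds shown, and "the series" means these compounds.

Of the compounds shown here, two built around the same core have so far been tested for their effect on the viability of Vero cells. Compound 1 `Cn1cc([N+](=O)[O-])cc1-c1nnc(Cc2ccccc2F)o1` and compound 2 `Cn1cc([N+](=O)[O-])cc1-c1nnc(-c2cccs2)o1` share that core and differ only in the group that hangs from it. In an ADME assay on Vero cells (Chlorocebus sabaeus) for cytotoxicity, read by MTT assay, with a stated time of 72 h (a higher number here means a weaker inhibitor, a lower number a stronger inhibitor), compound 1 gives 245000 nM, and compound 2 gives 521000 nM. Of these two numbers, compound 1 has the lower one, and the gap up to compound 2 is wider than the scatter that repeated measurements of this kind usually show.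

Compound 3 `O=[N+]([O-])c1c[nH]c(-c2nnc(Cc3ccccc3F)o2)c1` has not yet been measured in this assay. It differs from compound 1 in one place: hydrogen in place of methyl on an aromatic nitrogen. The nitro group and the fluorinated side chain are unchanged.

Among the compounds with values here, no measured pair in this set shows what swapping a methyl for a hydrogen on an aromatic nitrogen does to this read-out, so the expectation rests on the size of the change alone. A step from compound 1 to compound 3 of a 1.1-fold higher number from compound 1 to compound 3 (0.03 log units; within the scatter) is expected, that is, none beyond the scatter in either direction. Compound 3 is therefore estimated to give about 260000 nM in this assay, likely between 100000 nM and 650000 nM.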

Compound 3, half-maximal inhibitory concentration: 620000 nM
Compound 3: middle estimate off by 2.4-fold (0.38 log units), on the low side; measured number inside the range.
By their numbers in this assay, from the lowest: compound 1; then compounds 2 and 3 (each within the scatter of the next).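

In this assay, the aromatic nitrogen of the shared core proves not to be a silent position: swapping its methyl for hydrogen gives a 2.5-fold higher number from compound 1 to compound 3 (0.40 log units; beyond the scatter), a modest step but a real one for this kind of measurement. Within the data shown here, the nitro group and the fluorinated side chain stay the same, so this single change is the only difference within the pair, and the compound that keeps the methyl is the stronger inhibitor of the two. No measurement available here explains why losing one carbon atom at this place moves the number.

As far as these compounds go, this is a single pair, so it remains open whether the same swap would shift the number in the same direction on a compound carrying the side group of compound 2. Also open, from the compounds shown here alone, is what an ethyl group or a longer alkyl chain on that nitrogen would do, and so whether the number would keep moving as the chain grows or whether the methyl is already enough.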